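Swapping the Isopropyl Cap for a Dimethylaminomethyl Cap

This account rests on a few compounds, and the source may have more. Where it says the series, first, only, none or still open, it means among the compounds named here.

Measured so far in a functional assay on U2OS cells for antagonist activity at proto-oncogene Wnt-3 (Homo sapiens), read by a luciferase reporter, with a stated time of 18 h; on this read-out lower numbers stand for an effect already at smaller amounts and higher numbers for an effect only at larger amounts of compound:
compound 1 `O=C(CN1CCNCC1)N1CCC(NS(=O)(=O)c2cc(S(=O)(=O)c3ccccc3)ccc2C(F)(F)F)CC1` gives 250 nM
compound 2 `CC(C)(C)OC(=O)N1CCC[C@H]1C(=O)N1CCC(NS(=O)(=O)c2cc(S(=O)(=O)c3ccccc3)ccc2C(F)(F)F)CC1` gives 60 nM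
compound 3 `CC(C)C(=O)N1CCC[C@H]1C(=O)N1CCC(NS(=O)(=O)c2cc(S(=O)(=O)c3ccccc3)ccc2C(F)(F)F)CC1` gives 90 nM

Compound 3 stands second highest of the three numbers. Its nearest neighbour is compound 2, with a 1.5-fold higher number from compound 2 to compound 3 (0.18 log units; within the scatter), a step that stays inside the scatter. Its furthest is compound 1, from which a 2.8-fold lower number from compound 1 to compound 3 (0.44 log units; beyond the scatter) was seen, a modest but real gain.

Compound 4 `CN(C)CC(=O)N1CCC[C@H]1C(=O)N1CCC(NS(=O)(=O)c2cc(S(=O)(=O)c3ccccc3)ccc2C(F)(F)F)CC1` differs from compound 3 in one place: (dimethylamino)methyl in place of isopropyl on a carbonyl carbon. Going by the values given here, none of the measured steps exchanges these same two groups. The two steps that come closest, a 4.2-fold lower number from compound 1 to compound 2 (0.62 log units; beyond the scatter) and a 2.8-fold lower number from compound 1 to compound 3 (0.44 log units; beyond the scatter), each changed a larger part of the molecule, and the step of a 1.5-fold higher number from compound 2 to compound 3 (0.18 log units; within the scatter), which changed only the cap on the same carbonyl, stayed within the scatter. A single exchange at this cap is therefore expected to move this assay little, if at all, beyond the scatter in either direction. The expected step is a 1.3-fold higher number from compound 3 to compound 4 (0.12 log units; within the scatter). For compound 4 the estimate is 120 nM, with a range from 50 nM to 300 nM.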

Compound 4, half-maximal effective concentration: 310 nM
The estimate for compound 4 lay 2.6-fold (0.41 log units) below the measured number; measured number above the stated range.
By their numbers in this assay, from the lowest: compounds 2 and 3 (each within the scatter of the next); then compounds 1 and 4 (each within the scatter of the next).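

In this assay the cap on this carbonyl carbon proves able to move the number: (dimethylamino)methyl in place of isopropyl gives a 3.4-fold higher number from compound 3 to compound 4 (0.54 log units; beyond the scatter) and in place of tert-butoxy gives a 5.2-fold higher number from compound 2 to compound 4 (0.71 log units; beyond the scatter), whereas tert-butoxy and isopropyl stayed within the scatter of each other. The step to the earlier compound with the (piperazin-1-yl)methyl group reads a 1.2-fold higher number from compound 1 to compound 4 (0.09 log units; within the scatter), so a 1-acylpyrrolidin-2-yl unit alone does not secure the lower numbers of compound 2 and compound 3. Nothing available explains why this cap behaves differently.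

The compounds shown cannot separate the nitrogen of the new cap from its shape. An ether such as methoxymethyl, or a carbon-only chain such as isobutyl, would test that at this position.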